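The source may report more compounds than this note shows. Statements on the series, on what has been measured and on what is new or still open speak of the compounds shown alone.

Measured compounds:
compound 1 `CCc1nn(CC)c(C2CCN(C(=O)CN3CN(c4ccccc4)C4(CCN(C(=O)c5ccc(C(C)(C)C)cc5)CC4)C3=O)CC2)c1CC` with 4600 nM
compound 2 `CCc1nn(CC)c(C2CCN(C(=O)CN3CN(c4ccccc4)C4(CCN(C(=O)c5ccc(C(C)(C)C)cc5)CC4)C3=O)CC2)c1C` with 2500 nM

Going by the values given here, compound 2 stands at the lowest of the two numbers in an assay on HEK293 cells for displacement of a labelled ligand from NPC1-like intracellular cholesterol transporter 1 (Homo sapiens); on this read-out higher numbers stand for weaker inhibition and lower numbers for stronger inhibition; its nearest neighbour is compound 1, and the only measured step, a 1.8-fold lower number from compound 1 to compound 2 (0.26 log units; within the scatter), lies within the scatter, so the two compounds cannot be told apart on this read-out.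

Compound 3 `CC(C)(C)OC(=O)NCC1CCN(C(=O)CN2CN(c3ccccc3)C3(CCN(C(=O)c4ccc(C(C)(C)C)cc4)CC3)C2=O)CC1` is the unmeasured compound. It differs from compound 2 by ((tert-butoxycarbonyl)amino)methyl in place of 1,3-diethyl-4-methyl-1H-pyrazol-5-yl on a saturated ring carbon. Among the compounds with values here, no measured step bears on this change: the one measured step touches only a small group on the pyrazolyl ring, whereas here the whole ring is exchanged for an open chain carrying one hydrogen-bond donor. Compound 2 is expected to be the better reference, and the step of a 1.8-fold higher number from compound 2 to compound 3 (0.26 log units; within the scatter) is estimated to be a modest rise in number, with wide uncertainty in both directions. Compound 3 is therefore estimated at 4500 nM, expected to fall between 1200 nM and 17000 nM.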

Compound 3, half-maximal inhibitory concentration: 4200 nM
Estimate against measurement, compound 3: 1.1-fold (0.03 log units) above, within the range that was stated.
By their numbers in this assay, from the lowest: compounds 2, 3 and 1 (each within the scatter of the next).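

In this assay the exchange of 1,3-diethyl-4-methyl-1H-pyrazol-5-yl for ((tert-butoxycarbonyl)amino)methyl on a saturated ring carbon gives a 1.7-fold higher number from compound 2 to compound 3 (0.23 log units; within the scatter) and the exchange of 1,3,4-triethyl-1H-pyrazol-5-yl for the same group gives a 1.1-fold lower number from compound 1 to compound 3 (0.04 log units; within the scatter) and so neither exchange separates the compounds on this read-out. The position therefore accepts an open chain with no ring and a hydrogen-bond donor in place of a five-membered aromatic ring without a step beyond the scatter, which the earlier step, confined to a small group on the pyrazolyl ring, could not show. Nothing given here offers a reason for this outcome. 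

The compounds shown leave open how a free aminomethyl group, a carboxylic acid or a longer chain would read at this ring carbon. They also leave open whether any group here can move the number beyond the scatter.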